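One Further Methyl on the Chain of Compound 2

The source may hold more compounds than are shown below. What is called first, only, known or untested is meant among the compounds shown, and "the series" means these compounds.

In a functional assay on SW480 cells (Homo sapiens) for antiproliferative activity, read by MTT assay, with a stated time of 48 h (a higher number here means a weaker inhibitor, a lower number a stronger inhibitor), compound 1 (`CCCCCCC(CCO)n1cnc2c(OC)ncnc21`) gives > 50000 nM as a limit and not as a number. For the measured compounds named here, compound 2 (`CCCCCCCCCC(CCO)n1cnc2c(OC)ncnc21`) reads 3250 nM and holds the only exact number so far. Compound 3 (`CCCCCCCCCCC(CCO)n1cnc2c(OC)ncnc21`) differs from compound 2 by methyl in place of hydrogen on a saturated chain carbon, ten or more bonds along the chain from an aromatic nitrogen on the same chain. Going by the values given here, the only measured step bearing on this is an at least 15-fold lower number from compound 1 to compound 2 (1.18 log units; beyond the scatter) for propyl in place of hydrogen, so a smaller move in the same direction is expected for the methyl. The expected change is a 1.6-fold lower number from compound 2 to compound 3 (0.21 log units; within the scatter) and is likely to stay within the scatter. Compound 3 is estimated at 2000 nM with an expected range of 800 nM to 5000 nM in this assay.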

Compound 3, half-maximal inhibitory concentration: 8260 nM
Compound 3: middle estimate off by 4.1-fold (0.62 log units), on the low side; measured number outside the range, above it.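

In this assay, methyl in place of hydrogen at this far point on the chain gives a 2.5-fold higher number from compound 2 to compound 3 (0.41 log units; beyond the scatter), so the change reverses the direction seen in an at least 15-fold lower number from compound 1 to compound 2 (1.18 log units; beyond the scatter). The longer chain still leaves an at least 6.0-fold lower number from compound 1 to compound 3 (0.78 log units; beyond the scatter). Compound 1 stands at a limit and not at a number, so that step is only a bound: the limit of > 50000 nM in this assay, at which 1 of the 3 values shown sits.

The compounds shown leave open whether a longer chain would raise the number further. They also leave open how an amine or a carboxylic acid on the chain would read.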